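This account rests on a few compounds, and the source may have more. Where it says the series, first, only, none or still open, it means among the compounds named here.

Compound 1 `C=CCOc1cc(/C=C\c2cc(OC)c(OC)c(OC)c2)ccc1OC` gives 29000 nM in a functional assay on HT-29 cells (Homo sapiens) for inhibition, read by MTT assay, with a stated time of 3 days; on this read-out lower numbers stand for stronger inhibition and higher numbers for weaker inhibition. Compound 2 `COc1ccc(COc2cc(/C=C\c3cc(OC)c(OC)c(OC)c3)ccc2OC)cc1` gives 47000 nM. Compound 3 `COCOc1cccc(/C=C/CCCOc2cc(/C=C\c3cc(OC)c(OC)c(OC)c3)ccc2OC)c1` gives 59000 nM.

Among these three numbers compound 2 stands second highest; the values of compound 2 and compound 3 lie within the scatter of each other, as do those of compound 2 and compound 1. Compound 4 `COc1ccc(/C=C\c2cc(OC)c(OC)c(OC)c2)cc1OCCC/C=C/c1ccc(Br)cc1` differs from compound 2 by a group of 11 heavy atoms (10 carbon, 1 bromine; one six-membered aromatic ring of carbon only) in place of a group of 8 heavy atoms (7 carbon, 1 oxygen; one six-membered aromatic ring of carbon only), on a saturated chain carbon bound to an oxygen on an aromatic ring. Among the measured compounds shown here, the only measured step at the same place is a 1.6-fold higher number from compound 1 to compound 2 (0.21 log units; within the scatter), and it stayed within the scatter, so no step beyond the scatter is expected in this assay for compound 4 either. Compound 4 is therefore expected to give about 50000 nM, with a range from 20000 nM to 120000 nM, an estimated step of a 1.1-fold higher number from compound 2 to compound 4 (0.03 log units; within the scatter).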

Compound 4, half-maximal inhibitory concentration: 11000 nM
The estimate for compound 4 lay 4.5-fold (0.66 log units) above the measured number, and the stated range ends above it.
By their numbers in this assay, from the lowest: compound 4; then compounds 1, 2 and 3 (each within the scatter of the next, the first and the last beyond it).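

In this assay the place on a saturated chain carbon bound to an oxygen on an aromatic ring now gives steps beyond the scatter, with a 4.3-fold lower number from compound 2 to compound 4 (0.63 log units; beyond the scatter) and a 2.6-fold lower number from compound 1 to compound 4 (0.42 log units; beyond the scatter) as the new group enters. With the chain kept, 4-bromophenyl in place of 3-(methoxymethoxy)phenyl gives a 5.4-fold lower number from compound 3 to compound 4 (0.73 log units; beyond the scatter) so the group carried by the chain also counts, not the chain alone. Nothing available explains these steps. From the compounds shown here alone, whether the bromine itself carries the step stays open, as does what an amine or a carboxylic acid would give in place of 4-bromophenyl.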